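The source may hold more compounds than are shown below. What is called first, only, known or untested is meant among the compounds shown, and "the series" means these compounds.

- Compound 1 `CC(O)(CSc1cccc(S(F)(F)(F)(F)F)c1)C(=O)Nc1cccc(S(F)(F)(F)(F)F)c1`: 12900 nM
- Compound 2 `CC(O)(CSc1cccc(C(F)(F)F)c1)C(=O)Nc1cccc(S(F)(F)(F)(F)F)c1`: 12700 nM

In a functional assay on LNCaP cells (Homo sapiens) for antiproliferative activity, read by propidium iodide staining, with a stated time of 96 h (on this read-out higher numbers stand for weaker inhibition and lower numbers for stronger inhibition), compound 2 gives 12700 nM and compound 1 gives 12900 nM. These two values lie within the scatter of each other, so compound 2 does not stand apart from compound 1. Compound 3 `CC(O)(CSc1cccc(OC(F)(F)F)c1)C(=O)Nc1cccc(S(F)(F)(F)(F)F)c1` differs from compound 2 by trifluoromethoxy in place of trifluoromethyl on an aromatic carbon, which is trifluoromethoxy in place of trifluoromethyl on an aromatic carbon. Among the measured compounds shown here, only one measured step bears on this change, an exchange at the same place: a 1.0-fold lower number from compound 1 to compound 2 (0.01 log units; within the scatter), which is within the scatter. On the strength of that single step, no change beyond the scatter is expected in this assay, and no direction can be favoured. The expected step is a 1.1-fold lower number from compound 2 to compound 3 (0.02 log units; within the scatter). For compound 3 the estimated value is 12000 nM, with an expected range of 6000 nM to 24000 nM.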

Compound 3, half-maximal inhibitory concentration: 10900 nM
Estimate against measurement, compound 3: 1.1-fold (0.04 log units) above; measured number inside the range.
By their numbers in this assay, from the lowest: compounds 3, 2 and 1 (each within the scatter of the next).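

In this assay the oxygen that trifluoromethoxy brings in, with its one hydrogen-bond acceptor, does not separate the new compound from its neighbours: the exchange for trifluoromethyl gives a 1.2-fold lower number from compound 2 to compound 3 (0.07 log units; within the scatter) and the exchange for the pentafluorosulfanyl group gives a 1.2-fold lower number from compound 1 to compound 3 (0.07 log units; within the scatter) on the same aromatic carbon. Three different fluorine-bearing groups at this place now stand at one level, a pattern that holds for compounds 1, 2 and 3, with none of them going against it. Nothing measured here gives a reason for this flat result.

Going by these compounds, whether this place would respond to a group without fluorine, such as an amine, a carboxylic acid or a longer alkyl chain, stays open. On these data alone, the effect of exchanging the pentafluorosulfanyl group on the amide side, which all three compounds share, is also open.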